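Swapping the ester chain on a thiophene-bearing core

This account rests on a few compounds, and the source may have more. Where it says the series, first, only, none or still open, it means among the compounds named here.

Of the compounds shown here, two built on a shared core have been tested so far. Compound 1 `CC1=C(C(=O)OC(C)(C)C)C(c2cccs2)NC(=O)N1` gives 26% in an assay on membranes from CHO cells for displacement of a labelled ligand from adenosine receptor A1 (Homo sapiens), read by scintillation counting, with a stated time of 60 min, tested at 1 uM; a lower number here means less inhibition, a higher number more inhibition at the concentration tested (going by the name of the read-out). Compound 2 `CCCOC(=O)C1=C(C)NC(=O)NC1c1ccsc1` reaches 44% in this assay, the higher of the two numbers, and its gap to compound 1 lies beyond the usual scatter. Compound 1 and compound 2 differ in more than one place, so their two values say nothing about any single change.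

Compound 3 `CC1=C(C(=O)OC(C)(C)C)C(c2ccsc2)NC(=O)N1` differs from compound 2 in one place only: tert-butyl in place of propyl on an oxygen next to a carbonyl group. Within the data shown here, no step between measured compounds isolates this change, so the expectation rests on compound 1, whose tert-butyl ester gives 26% while sitting on a different thiophene attachment. A moderate fall is expected, so compound 3 is estimated to show a number 10 percentage points lower from compound 2 to compound 3 (within the scatter). Compound 3 is therefore expected to give about 34%, within a range from 15% to 55%.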

Compound 3, a percentage reported as inhibition, at one concentration (the size of the read-out at that concentration, not a potency): 15%
The estimate for compound 3 lay 19 percentage points above the measured number, and the stated range covers the measured number.
By their numbers in this assay, from the lowest: compound 3; then compound 1; then compound 2.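

Taken alone, tert-butyl in place of propyl on an oxygen next to a carbonyl group gives a number 29 percentage points lower from compound 2 to compound 3 (beyond the scatter) in this assay, so the ester chain at this position affects the read-out. With tert-butyl held constant, thiophen-3-yl in place of thiophen-2-yl on a saturated ring carbon gives a number 11 percentage points lower from compound 1 to compound 3 (beyond the scatter), showing that the thiophene attachment also affects the read-out, at least with this ester. Nothing available gives a reason for either step.

Going by these compounds, each change is seen only once, so it remains open whether the ester step would be similar on a thiophen-2-yl compound, or the thiophene step with a propyl ester. Also open, on these data alone, is how a longer chain such as butyl, or a hydrogen on that oxygen, which would make a carboxylic acid, would compare.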